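The source may hold more compounds than are shown below. What is called first, only, known or untested is meant among the compounds shown, and "the series" means these compounds.

Compound 1 `C=CC1=C(C(=O)NCc2ccccc2)C(c2ccc(OC)c(OC)c2)OC1`: in a functional assay on QGY7701 cells (Homo sapiens) for cytotoxicity, read by MTT assay, with a stated time of 24 h (on this read-out lower numbers stand for stronger inhibition and higher numbers for weaker inhibition), compound 1 gives > 100000 nM, a limit of the assay.
Compound 2 `C=CC1=C(C(=O)O)C(c2ccc(F)cc2)OC1`: in this assay compound 2 gives > 100000 nM, again a limit.
Compound 3 `C=CC1=C(C(=O)NCC(C)C)C(c2ccc(Cl)c(Cl)c2)OC1`: in this assay compound 3 gives > 100000 nM, also a limit.

No numbered value is therefore known for compound 3; it sits, with the two others, at the limit of > 100000 nM in this assay, at which 3 of the 3 values shown sit. For the measured compounds named here, nothing in this set separates one compound from another, and no step between measured compounds can be drawn.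

Compound 4 `C=CC1=C(C(=O)NC(C)(C)C)C(c2ccc(Cl)c(Cl)c2)OC1` differs from compound 3 in one place: tert-butyl in place of isobutyl on an amide-type nitrogen. The two have the same atoms, joined differently. Going by the values given here, since every compound so far has stayed at the limit in this assay, and the change keeps the size of the group on the nitrogen unchanged, no step beyond the usual scatter is expected in either direction. Compound 4 is expected to come out at 150000 nM, within a range from 50000 nM to 500000 nM, most probably reported only as a limit once more. The expected step, a step that the limit leaves unreadable from compound 3 to compound 4, is one that the scatter of this assay would cover.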

Compound 4, half-maximal inhibitory concentration: > 100000 nM
Compound 4: a limit, no number; the forecaster's own chance of this, stated with the estimate: 85%; the middle value does not contradict the limit.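

In this assay compound 4 gives > 100000 nM, a limit and not a number. Compound 3 also stands at a limit, so no step can be read between compound 3 and compound 4. The compounds shown leave open whether any change to them would yield a measurable value in this assay: the limit of > 100000 nM in this assay, at which 4 of the 4 values shown sit.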